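Lengthening the Chain to the Phenyl Group Once More

The source may hold more compounds than are shown below. What is called first, only, known or untested is meant among the compounds shown, and "the series" means these compounds.

For the measured compounds named here, in an assay on isolated protein for inhibition of histone deacetylase HD2 (Zea mays) (on this read-out higher numbers stand for weaker inhibition and lower numbers for stronger inhibition), compound 2 `Cn1cc(C(=O)CCCCCc2ccccc2)cc1/C=C/C(=O)NO` gives 71 nM, the lower of the two numbers so far, yet within the scatter of its only neighbour, compound 1 `Cn1cc(C(=O)CCCCc2ccccc2)cc1/C=C/C(=O)NO`, which gives 110 nM. Going by the values given here, the one measured step, a 1.5-fold lower number from compound 1 to compound 2 (0.19 log units; within the scatter), bears directly on the present case. Compound 3 `Cn1cc(C(=O)CCCCCCc2ccccc2)cc1/C=C/C(=O)NO` differs from compound 2 by benzyl in place of phenyl on a saturated chain carbon, five bonds along the chain from a carbonyl carbon. Since that earlier step stayed within the scatter, no step beyond the scatter is expected here. Compound 3 is therefore estimated at 60 nM, with a range from 30 nM to 140 nM. The expected step is a 1.2-fold lower number from compound 2 to compound 3 (0.07 log units; within the scatter).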

Compound 3, half-maximal inhibitory concentration: 266 nM
For compound 3 the middle estimate is 4.4-fold (0.65 log units) below the measured one, and the stated range ends below it.
By their numbers in this assay, from the lowest: compounds 2 and 1 (each within the scatter of the next); then compound 3.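

In this assay, for the compounds shown here, the position does not tolerate every extension: benzyl in place of phenyl, five bonds along the chain from a carbonyl carbon, brings a 3.7-fold higher number from compound 2 to compound 3 (0.57 log units; beyond the scatter) and is the first step here beyond the scatter. Phenethyl in place of phenyl, four bonds along the chain from a carbonyl carbon, brings a 2.4-fold higher number from compound 1 to compound 3 (0.38 log units; beyond the scatter) as well, so compound 3 stands apart from both shorter-chain compounds. Nothing shown explains this turn. On these data alone, whether a longer chain raises the number further remains open, as does the effect of an amine or a carboxylic acid in place of the phenyl.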